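Nitro Substitution on a Carboxylic Acid Analogue

The source may report more compounds than this note shows. Statements on the series, on what has been measured and on what is new or still open speak of the compounds shown alone.

In a functional assay on SGC-7901 cells (Homo sapiens) for antiproliferative activity, read by MTT assay, with a stated time of 72 h (on this read-out lower numbers stand for stronger inhibition and higher numbers for weaker inhibition), compound 1 `COc1ccc(-c2sccc2-c2cc(OC)c(OC)c(OC)c2)cc1` gives 5470 nM. Compound 2 `COc1ccc(-c2sccc2-c2cc(OC)c(OC)c(OC)c2)cc1[N+](=O)[O-]` differs by nitro in place of hydrogen on an aromatic carbon, and this change made a 1.7-fold lower number from compound 1 to compound 2 (0.22 log units; within the scatter). Compound 3 `COc1ccc(-c2cc(C(=O)O)sc2-c2cc(OC)c(OC)c(OC)c2)cc1` is built on a different core; the difference between the two cores is not broken down here. In this assay compound 3 gives 4220 nM, and compound 2 gives 3310 nM, so the three measured numbers lie within the scatter of one another. Compound 4 `COc1ccc(-c2cc(C(=O)O)sc2-c2cc(OC)c(OC)c(OC)c2)cc1[N+](=O)[O-]` differs from compound 3 by nitro in place of hydrogen on an aromatic carbon, the same change seen between compound 1 and compound 2. Because the earlier step of a 1.7-fold lower number from compound 1 to compound 2 (0.22 log units; within the scatter) stayed within the scatter, a step of similar size is expected here, a 1.5-fold lower number from compound 3 to compound 4 (0.18 log units; within the scatter). For compound 4 the estimate is 2800 nM, with a range from 1400 nM to 5600 nM.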

Compound 4, half-maximal inhibitory concentration: 21600 nM
Compound 4: middle estimate off by 7.7-fold (0.89 log units), on the low side, outside the stated range (above it).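

In this assay, nitro in place of hydrogen on an aromatic carbon gave a 5.1-fold higher number from compound 3 to compound 4 (0.71 log units; beyond the scatter). The same change did not carry over in the same way from one core to the other: the same change on two cores in this assay, a 1.7-fold lower number (0.22 log units; within the scatter) from compound 1 to compound 2 and a 5.1-fold higher number (0.71 log units; beyond the scatter) from compound 3 to compound 4, 8.5-fold (0.93 log units) apart, beyond the scatter of two such steps

This shows that, for these two pairs, the result of the change depends on the core it is placed on, but with one pair per core it does not show which feature of the cores is responsible, or why. The compounds shown leave open whether the gap follows the carboxylic acid of compound 3 and compound 4, which a methyl ester or an amide on that core could test. They also leave open how an amine in place of the nitro would behave on each core.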